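Urea in Place of Benzyl on the Shared Core

This account rests on a few compounds, and the source may have more. Where it says the series, first, only, none or still open, it means among the compounds named here.

For the measured compounds named here, in a functional assay on HeLa cells (Homo sapiens) for antiproliferative activity, with a stated time of 24 h (a higher number here means a weaker inhibitor, a lower number a stronger inhibitor), compound 2 `NC(=O)c1c(NC(=O)c2ccccc2Cl)sc2c1CCN(Cc1c(Cl)cccc1Cl)C2` gives 28800 nM, the only number recorded so far. Compound 1 `NC(=O)c1c(NC(=O)c2ccccc2Cl)sc2c1CCN(Cc1ccccc1F)C2` reaches only a limit of this assay, > 50000 nM. Going by the values given here, the single measured step is an at least 1.7-fold lower number from compound 1 to compound 2 (0.23 log units; that floor lies within the scatter); its floor sits within the scatter (the limit of > 50000 nM in this assay, at which 1 of the 2 values shown sits), so it offers no clear direction. Among the compounds with values here, compound 3 `NC(=O)c1c(NC(=O)c2ccccc2Cl)sc2c1CCN(C(=O)Nc1ccccc1Cl)C2` carries (2-chlorophenyl)carbamoyl in place of 2,6-dichlorobenzyl on an amine nitrogen in a ring, a change at the same nitrogen but of a different kind, and no measured step directly matches it. Compound 3 is therefore expected to stay near compound 2, at 30000 nM within 8000 nM to 100000 nM, meaning an estimated step of a 1.0-fold higher number from compound 2 to compound 3 (0.02 log units; within the scatter) with a fair chance of a limit only.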

Compound 3, half-maximal inhibitory concentration: 45400 nM
Beside the measured number, compound 3's estimate is 1.5-fold (0.18 log units) below it; the range from low to high includes it.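

In this assay, (2-chlorophenyl)carbamoyl in place of 2,6-dichlorobenzyl on an amine nitrogen in a ring gives a 1.6-fold higher number from compound 2 to compound 3 (0.20 log units; within the scatter). This shows that a carbamoyl link, carrying a hydrogen-bond donor and a hydrogen-bond acceptor, can replace the benzyl type of group at this nitrogen with no difference beyond the scatter. The second new step is an at least 1.1-fold lower number from compound 1 to compound 3 (0.04 log units; that floor lies within the scatter). It cannot be read because compound 1 stands only at a limit: the limit of > 50000 nM in this assay, at which 1 of the 3 values shown sits.

Going by these compounds, whether an acetyl or a methylsulfonyl group on this nitrogen would move the number beyond the scatter stays open. So does whether an unsubstituted phenyl on the carbamoyl would differ from the 2-chlorophenyl.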